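Moving the fluorine on a benzyl triazole dithiocarbamate

The compounds below may be only part of what the source reports. "The series", "measured", "known", "first", "only" and "open" are said of these compounds alone.

Compound 1 `Fc1ccc(Cn2cc(CSC(=S)N3CCNCC3)nn2)cc1`: 49900 nM
Compound 2 `Cc1ccc(Cn2cc(CSC(=S)N3CCN(C(=O)OC(C)(C)C)CC3)nn2)cc1`: 19700 nM

In a functional assay on MCF7 cells (Homo sapiens) for inhibition, read by MTT assay, with a stated time of 72 h (a lower number here means a stronger inhibitor, a higher number a weaker inhibitor), compound 1 gives 49900 nM, the higher of the two numbers, so it is the weaker inhibitor of the pair; compound 2 gives 19700 nM, a difference beyond the usual scatter. Compound 3 `Fc1ccccc1Cn1cc(CSC(=S)N2CCNCC2)nn1` differs from compound 1 in one place: 2-fluorophenyl in place of 4-fluorophenyl on a saturated chain carbon bound to an aromatic nitrogen. Going by the values given here, no measured pair shows what such a move does here, so the expected step from compound 1 to compound 3 is a 1.1-fold lower number from compound 1 to compound 3 (0.04 log units; within the scatter), none beyond the scatter. Compound 3 is therefore estimated at 45000 nM, within 15000 nM to 140000 nM.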

Compound 3, half-maximal inhibitory concentration: 33200 nM
Compound 3: middle estimate off by 1.4-fold (0.13 log units), on the high side, within the range that was stated.
By their numbers in this assay, from the lowest: compounds 2, 3 and 1 (each within the scatter of the next, the first and the last beyond it).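

In this assay, placing 2-fluorophenyl in place of 4-fluorophenyl on a saturated chain carbon bound to an aromatic nitrogen gives a 1.5-fold lower number from compound 1 to compound 3 (0.18 log units; within the scatter) and so provides the first direct test of this change. For this pair, relocating the fluorine on the phenyl ring leaves the two readings indistinguishable. No independent evidence here explains the result. The compounds shown leave open whether a larger change at this place, such as a plain phenyl, a pyridine ring or a phenyl bearing a carboxylic acid, would give a step beyond the scatter.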